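Acetoxy in place of acetamido on the chain

The source may report more compounds than this note shows. Statements on the series, on what has been measured and on what is new or still open speak of the compounds shown alone.

Of the compounds shown here, three sharing one core have been tested in a functional assay on HCT-116 cells (Homo sapiens) for antiproliferative activity, read by sulforhodamine B assay, with a stated time of 72 h; on this read-out higher numbers stand for weaker inhibition and lower numbers for stronger inhibition. Compound 1 `Cn1ncc(Cl)c1-c1cc(C(=O)N[C@@H]2CN[C@H](CCNS(C)(=O)=O)C[C@H]2c2ccc(F)c(F)c2)oc1Cl`, with methanesulfonamido on its chain, gives 920 nM. Compound 2 `Cn1ncc(Cl)c1-c1cc(C(=O)N[C@@H]2CN[C@H](CCO)C[C@H]2c2ccc(F)c(F)c2)oc1Cl`, with hydroxy at that place, gives 360 nM. Compound 3 `CC(=O)NCC[C@@H]1C[C@@H](c2ccc(F)c(F)c2)[C@H](NC(=O)c2cc(-c3c(Cl)cnn3C)c(Cl)o2)CN1`, with acetamido there, gives 920 nM, level with compound 1, and together they hold the highest of the three numbers.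

Compound 4 `CC(=O)OCC[C@@H]1C[C@@H](c2ccc(F)c(F)c2)[C@H](NC(=O)c2cc(-c3c(Cl)cnn3C)c(Cl)o2)CN1` has not been measured. It differs from compound 3 in one place: acetoxy in place of acetamido on a saturated chain carbon, two bonds along the chain from a saturated ring carbon. That is acetoxy in place of acetamido on a saturated chain carbon, two bonds along the chain from a saturated ring carbon.

Going by the values given here, no measured step makes this exact swap, so only related steps can guide the expectation. Changing methylsulfonyl to acetyl on an amine nitrogen gave no change at the digits printed from compound 1 to compound 3 (within the scatter). Changing hydroxy to acetamido gave a 2.6-fold higher number from compound 2 to compound 3 (0.41 log units; beyond the scatter), a modest step, and changing methanesulfonamido to hydroxy gave a 2.6-fold lower number from compound 1 to compound 2 (0.41 log units; beyond the scatter), equally modest. Acetoxy joins the chain through oxygen, as hydroxy does in compound 2 at 360 nM, yet it keeps the acetyl of compound 3 at 920 nM. A small move part of the way towards the lower number is therefore expected, within the scatter: a 1.5-fold lower number from compound 3 to compound 4 (0.19 log units; within the scatter). Compound 4 is estimated at 600 nM, with an expected range from 270 nM to 1300 nM.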

Compound 4, half-maximal inhibitory concentration: 690 nM
Compound 4: the middle estimate sits 1.2-fold (0.06 log units) below what was measured, and the stated range covers the measured number.
By their numbers in this assay, from the lowest: compounds 2, 4, 1 and 3 (each within the scatter of the next, the first and the last beyond it).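

In this assay, replacing the acetamido nitrogen with oxygen gives a 1.3-fold lower number from compound 3 to compound 4 (0.12 log units; within the scatter), so the chain can go from one hydrogen-bond donor to none, and from one hydrogen-bond acceptor to two, without a step beyond the scatter. Adding acetyl to the hydroxy oxygen gives a 1.9-fold higher number from compound 2 to compound 4 (0.28 log units; within the scatter), and acetoxy in place of methanesulfonamido gives a 1.3-fold lower number from compound 1 to compound 4 (0.12 log units; within the scatter), which places compound 4 within the scatter of all three earlier compounds, even though a 2.6-fold higher number from compound 2 to compound 3 (0.41 log units; beyond the scatter) lies beyond it. Nothing available explains how these groups produce these read-outs.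

The compounds shown carry only neutral groups at the end of this 2-carbon chain, so it remains open how a primary amine or a carboxylic acid would read at the same place. From the compounds shown here alone, it is also open whether a longer chain bearing the same acetoxy group, or a simple methoxy group in its place, would stay within the same narrow band of values.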